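A few compounds are considered here, and "the series" means these few. Any claim that something is new, unique, unknown or untested is made for them only; others in the source may bear on it.

Measured so far in an assay for inhibition of serine/threonine-protein kinase PLK2 (Homo sapiens), read by FRET and Z'-LYTE, with a stated time of 1 h; a higher number here means a weaker inhibitor, a lower number a stronger inhibitor:

- compound 1, `CCC1C(=O)N(C)c2cnc(Nc3ccc(S(=O)(=O)NC)cc3)nc2N1c1ccn(C)n1`, gives 71.6 nM
- compound 2, `CC[C@@H]1C(=O)N(C)c2cnc(-n3ccc4ccccc43)nc2N1C1CCCC1`, gives 355 nM
- compound 3, `CCC1C(=O)N(C)c2cnc(-n3ccc4cc(F)ccc43)nc2N1c1ccn(C)n1`, gives 1500 nM

Compound 1 stands lowest of the three numbers, and both gaps lie beyond the usual scatter: compound 2 is the nearest to it and compound 3 the furthest, so within this small set compound 1 is the strongest inhibitor. For the measured compounds named here, no pair among the measured compounds differs in a single place, so none of these gaps can be read as a clean step tied to one structural change; the three compounds differ from one another in more than one position.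

Compound 4, `CCCCNS(=O)(=O)c1ccc(Nc2ncc3c(n2)N(c2ccn(C)n2)C(CC)C(=O)N3C)cc1`, is not yet measured. It differs from compound 1 by propyl in place of hydrogen on a saturated chain carbon bound to a sulfonamide nitrogen. The change sits on the substituent of the sulfonamide nitrogen of the anilino side chain and leaves the rest of the structure of compound 1 untouched. Going by the values given here, with no comparable single-point step among the measured compounds, there is no direct precedent for its size. The expectation is a small step, if any, from compound 1 to compound 4 in this assay, perhaps a slight weakening, but most likely not beyond the scatter: a 1.4-fold higher number from compound 1 to compound 4 (0.15 log units; within the scatter). Compound 4 is accordingly estimated at 100 nM, with a range from 30 nM to 350 nM.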

Compound 4, half-maximal inhibitory concentration: 191 nM
For compound 4 the middle estimate is 1.9-fold (0.28 log units) below the measured one, and the stated range covers the measured number.
By their numbers in this assay, from the lowest: compound 1; then compounds 4 and 2 (each within the scatter of the next); then compound 3.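

Working from compound 1, the change from methylsulfamoyl to butylsulfamoyl in this assay gives a 2.7-fold higher number from compound 1 to compound 4 (0.43 log units; beyond the scatter) and is the first step in this series that can be tied to one structural change. It shows that the substituent on the sulfonamide nitrogen is not a silent position, as propyl in place of hydrogen on this saturated chain carbon moves the number beyond the scatter. The size of the step is modest, and compound 4 at 191 nM remains measurable in this assay, so this position accepts a butyl group with some loss of inhibition, while no supporting data bear on the origin of the step.

As far as these compounds go, a single step cannot define a trend with chain length, so it remains open whether an ethyl or propyl group would fall between compound 1 and compound 4 or whether a longer chain would weaken inhibition further. The compounds shown also leave open how the unsubstituted sulfamoyl group, or a chain ending in an amine or a carboxylic acid, would behave at this position.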